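Benzyl replaces aryl on the amine of the shared core

The compounds below may be only part of what the source reports. "The series", "measured", "known", "first", "only" and "open" are said of these compounds alone.

Three anilino analogues of one core have been measured. In a functional assay on HeLa cells (Homo sapiens) for inhibition, read by sulforhodamine B assay (on this read-out higher numbers stand for weaker inhibition and lower numbers for stronger inhibition), compound 1 `CCCc1ccc(NC2=CC(=O)c3nc4n(c3C2=O)[C@H]2OC[C@@H](O)[C@H]2OC4)cc1` gives 4990 nM, compound 2 `O=C1C(Nc2ccc(Br)cc2)=CC(=O)c2c1nc1n2[C@H]2OC[C@@H](O)[C@H]2OC1` gives 5220 nM and compound 3 `O=C1C=C(Nc2ccccc2F)C(=O)c2c1nc1n2[C@H]2OC[C@@H](O)[C@H]2OC1` gives 5120 nM. Compound 2 holds the highest of the three numbers, yet its gaps to compound 1 and compound 3 are both within the scatter, so the three stand together. Within the data shown here, the single step in hand, a 1.0-fold higher number from compound 1 to compound 3 (0.01 log units; within the scatter), shows that swapping one aryl group for another left the read-out unchanged. Compound 4 `O=C1C(NCc2ccccc2)=CC(=O)c2c1nc1n2[C@H]2OC[C@@H](O)[C@H]2OC1` differs from compound 2 by benzyl in place of 4-bromophenyl on an amine nitrogen. Among the measured compounds shown here, no measured step exchanges an aryl for a benzyl group, so this account expects no step beyond the scatter, a 1.1-fold higher number from compound 2 to compound 4 (0.02 log units; within the scatter), and estimates compound 4 at 5500 nM with a range of 2000 nM to 15000 nM.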

Compound 4, half-maximal inhibitory concentration: 11000 nM
Estimate against measurement, compound 4: 2.0-fold (0.30 log units) below, and the stated range covers the measured number.
By their numbers in this assay, from the lowest: compounds 1, 3 and 2 (each within the scatter of the next); then compound 4.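

In this assay, among these compounds, benzyl in place of 4-bromophenyl on the amine nitrogen gives a 2.1-fold higher number from compound 2 to compound 4 (0.32 log units; beyond the scatter) and is the first step at this position to lie beyond the scatter. The swap of one aryl group for another gave only a 1.0-fold higher number from compound 1 to compound 3 (0.01 log units; within the scatter) and so did not show that this position responds to what it carries, though the step here is modest. Nothing available bears on the reason for this step. As far as these compounds go, whether a 4-bromobenzyl group would give the same step remains open, as does whether a phenethyl group would take the number further.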